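Swapping the Carbamoyl Group for a Methyl Ester Chain

The source may report more compounds than this note shows. Statements on the series, on what has been measured and on what is new or still open speak of the compounds shown alone.

Compound 1 `Cc1nc2c(OCc3ccccc3)cccn2c1C(N)=O` carries a carbamoyl group on an aromatic carbon of its core. In a functional assay on the whole organism (stomach) for inhibition, with Canis familiaris (Canis lupus familiaris) as the target, at a dose of 5 mg/kg by the intravenous route (a higher number here means a stronger effect of the compound at the dose given, a lower number a weaker effect), compound 1 gives 2%. Among the three compounds measured so far, compound 1 stands second highest. Its nearest neighbour is compound 3 `Cc1nc2c(OCc3ccccc3)cccn2c1CS(C)(=O)=O`, which in this assay gives 0%, a gap within the scatter. Its furthest neighbour is compound 2 `Cc1nc2c(OCc3ccccc3)cccn2c1CCC#N`, which in this assay gives 20%.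

Compound 4 `COC(=O)Cc1c(C)nc2c(OCc3ccccc3)cccn12` has not yet been measured. It differs from compound 1 in one place: (methoxycarbonyl)methyl in place of carbamoyl on an aromatic carbon

For the measured compounds named here, two measured steps bear on this change, since each also replaces the carbamoyl group on the same aromatic carbon with a chain that has no hydrogen-bond donor. The step of a number 18 percentage points higher from compound 1 to compound 2 (beyond the scatter) was a modest rise. The step of a number 2 percentage points lower from compound 1 to compound 3 (within the scatter) stayed within the scatter. The related step of a number 20 percentage points lower from compound 2 to compound 3 (beyond the scatter) shows that such chains can differ from one another by a modest amount. A small rise or no change beyond the scatter is therefore expected for compound 4 in this assay. The expected step is a number 6 percentage points higher from compound 1 to compound 4 (within the scatter). For compound 4 a reading of 8% is estimated, with a range from 0% to 25%.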

Compound 4, a percentage reported as inhibition, in the whole organism at one dose (the size of the read-out at that dose, not a potency): 16%
Estimate against measurement, compound 4: 8 percentage points below, and the stated range covers the measured number.
By their numbers in this assay, from the lowest: compounds 3 and 1 (each within the scatter of the next); then compounds 4 and 2 (each within the scatter of the next).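

In this assay, the step to the (methoxycarbonyl)methyl chain gives a number 14 percentage points higher from compound 1 to compound 4 (beyond the scatter), so the 2-cyanoethyl chain of compound 2 is no longer the only replacement of carbamoyl at this aromatic carbon to give a rise beyond the scatter. The ester and nitrile chains cannot be separated (a number 4 percentage points lower from compound 2 to compound 4 (within the scatter)), whereas the methylsulfonyl group stands apart from the ester (a number 16 percentage points higher from compound 3 to compound 4 (beyond the scatter)), so what sits on the saturated chain carbon matters, and compound 3 goes against any rule that losing carbamoyl alone raises the effect (a number 2 percentage points lower from compound 1 to compound 3 (within the scatter)). No measurement here gives a reason for these differences.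

Still open, on these data alone, is how the reading would respond at this same aromatic carbon to a carboxylic acid or an amine at the end of the chain, or to a longer chain carrying the methyl ester. All these readings also come from a single dose, so they show the size of the effect at that dose and leave the potency of compounds 2 and 4 undefined.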